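The compounds below may be only part of what the source reports. "The series", "measured", "known", "first", "only" and "open" are said of these compounds alone.

The study concerns two measured compounds and one still to be measured, all built on a shared core. Compound 1 `CCOC(=O)c1c(-c2cccc(Cl)c2)[nH]c2cccc(OC)c2c1=O` was tested in a physicochemical assay for solubility, in phosphate buffer, at pH 7.4; a higher number here means a more soluble compound, a lower number a less soluble compound. In this assay compound 1 gives > 100000 nM, which is a limit of the measurement and not a number. Going by these compounds, the point in question is the limit of > 100000 nM in this assay, at which 1 of the 2 values shown sits, so where compound 1 truly stands beyond it is unknown. Compound 2 `CCOC(=O)c1c(-c2ccccc2Cl)[nH]c2cc(OC)ccc2c1=O` differs from compound 1 in more than one place, and in this assay compound 2 gives 28000 nM. Within the data shown here, the two values show only that compound 1 sits at the limit while compound 2 sits below it.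

Compound 3 `CCOC(=O)c1c(-c2cccc(OC)c2)[nH]c2cccc(OC)c2c1=O` is the compound not yet measured. It differs from compound 1 in one place: methoxy in place of chloro on an aromatic carbon. Among the measured compounds shown here, no measured pair matches this change, so the expectation rests on where compound 1 stands. Since compound 1 is at the limit with > 100000 nM, the expected step in this assay is a step that the limit leaves unreadable from compound 1 to compound 3, essentially none beyond the scatter. Compound 3 is therefore expected to give about 150000 nM, within a range from 50000 nM to 500000 nM, most likely again reported only as a limit.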

Compound 3, solubility: > 100000 nM
Compound 3 gave a limit, no number; the forecaster's own chance of this, stated with the estimate: 65%; the middle value does not contradict the limit.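

In this assay compound 3 gives > 100000 nM, a limit and not a number, just as compound 1 ends at a limit, so no step can be read between compound 1 and compound 3: the limit of > 100000 nM in this assay, at which 2 of the 3 values shown sit.

The compounds shown leave open where compound 1 and compound 3 truly stand beyond that limit, and whether methoxy in place of chloro on an aromatic carbon shifts the read-out in this assay at all.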